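Removing One Methoxy Group: An Expectation for Compound 4

The compounds below may be only part of what the source reports. "The series", "measured", "known", "first", "only" and "open" are said of these compounds alone.

Measured so far in a functional assay on MDA-MB-231 cells (Homo sapiens) for inhibition, read by MTT assay, with a stated time of 48 h; a lower number here means a stronger inhibitor, a higher number a weaker inhibitor:
Compound 1, `COc1ccc2c(c1)C/C(=C\c1cc(-c3cc(OC)c(OC)c(OC)c3)n[nH]1)C2=O`, gives 2000 nM.
Compound 2, `COc1cc(-c2cc(/C=C3\Cc4ccccc4C3=O)[nH]n2)cc(OC)c1OC`, gives 7100 nM.
Compound 3, `COc1cc(C(=O)/C=C/c2cc(-c3cc(OC)c(OC)c(OC)c3)n[nH]2)cc(OC)c1OC`, gives 700 nM.

Compound 3 has the lowest number of the three, and its gap to compound 1 and to compound 2 is beyond the scatter in each case. How the core of compound 3 differs from the core of compound 1 is not broken down here.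

Within the first pair, the change hydrogen in place of methoxy on an aromatic carbon produced a step of a 3.6-fold higher number from compound 1 to compound 2 (0.55 log units; beyond the scatter) in this assay.

Compound 4, `COc1ccc(-c2cc(/C=C/C(=O)c3cc(OC)c(OC)c(OC)c3)[nH]n2)cc1OC`, is not yet measured. It differs from compound 3 by hydrogen in place of methoxy on an aromatic carbon. Going by the values given here, this is the same kind of change as the one from compound 1 to compound 2, but not the same: in compound 1 the ring carrying the methoxy group is part of a fused or bridged system of two rings, with the position meta and para to a fused ring, whereas in compound 3 the position is on a ring of carbon only, ortho to a methoxy group, meta to a large group and meta to a methoxy group.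

Because the earlier removal gave a 3.6-fold higher number from compound 1 to compound 2 (0.55 log units; beyond the scatter), a step of roughly that size, a 3.3-fold higher number from compound 3 to compound 4 (0.52 log units; beyond the scatter), is expected from compound 3 to compound 4, with wider uncertainty since the surroundings differ. Compound 4 is therefore estimated at 2300 nM, likely between 800 nM and 6500 nM.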

Compound 4, half-maximal inhibitory concentration: 2000 nM
Compound 4: middle estimate off by 1.2-fold (0.06 log units), on the high side; the measured number falls inside the stated range.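

In this assay, putting hydrogen in place of a methoxy group on an aromatic carbon again weakens inhibition, giving a 2.9-fold higher number from compound 3 to compound 4 (0.46 log units; beyond the scatter). Set beside the earlier removal, the change carries over from one core to the other with much the same size, and the two steps cannot be told apart: the same change on two cores in this assay, a 3.6-fold higher number (0.55 log units; beyond the scatter) from compound 1 to compound 2 and a 2.9-fold higher number (0.46 log units; beyond the scatter) from compound 3 to compound 4, 1.2-fold (0.09 log units) apart, within the scatter of two such steps Still, this rests on just two pairs of compounds, with the methoxy group leaving a different place in each, so it does not establish a rule for other cores or other positions, and a matching step size does not explain why the number rises.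

The compounds shown leave open what other groups would do at this place on the ring, since only methoxy and hydrogen appear there, and a hydroxyl group, a fluorine atom, an amine or a longer ether chain such as ethoxy could each give a different result. Going by these compounds, it also remains open whether taking away one of the other methoxy groups, on either aromatic ring of compound 3, would produce a step of similar size.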